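The source may hold more compounds than are shown below. What is called first, only, known or untested is meant among the compounds shown, and "the series" means these compounds.

Compound 3, with the structure `CN(C)c1[nH]ccc2ncnc1-2`, is the starting point of this step. In a functional assay (Homo sapiens) for inhibition of Nucleic Acid, tested at 100 uM (a lower number here means less inhibition, a higher number more inhibition at the concentration tested (going by the name of the read-out)), compound 3 gives 8%, a number that sits alongside those of its two relatives: compound 1, `Clc1[nH]ccc2ncnc1-2`, gives 6% in this assay, and compound 2, `OCCNc1[nH]ccc2ncnc1-2`, gives 3%; the three numbers lie within the scatter of one another, so none can be set apart from the rest.

Compound 4 has the structure `[N-]=[N+]=Nc1[nH]ccc2ncnc1-2` and differs from compound 3 in a single place: azido in place of dimethylamino on an aromatic carbon.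

Three measured steps at the same aromatic carbon bear on this change. The replacement of chloro by dimethylamino gave a number 2 percentage points higher from compound 1 to compound 3 (within the scatter), that of (2-hydroxyethyl)amino by dimethylamino gave a number 5 percentage points higher from compound 2 to compound 3 (within the scatter), and that of chloro by (2-hydroxyethyl)amino gave a number 3 percentage points lower from compound 1 to compound 2 (within the scatter). Among the measured compounds shown here, every exchange at this position so far has left the read-out flat, and no measured compound carries azido, so nothing points either way. Compound 4 is therefore expected to show a number 2 percentage points lower from compound 3 to compound 4 (within the scatter), a step that stays within the scatter. On that basis compound 4 is estimated at 6%, within a range from -6% to 20%.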

Compound 4, a percentage reported as inhibition, at one concentration (the size of the read-out at that concentration, not a potency): 20%
The estimate for compound 4 lay 14 percentage points below the measured number; low and high end bracket the measured number.
By their numbers in this assay, from the lowest: compounds 2, 1 and 3 (each within the scatter of the next); then compound 4.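

In this assay, azido is the only group shown at this aromatic carbon to move the read-out beyond the scatter: replacing dimethylamino gave a number 12 percentage points higher from compound 3 to compound 4 (beyond the scatter) while replacing (2-hydroxyethyl)amino gave a number 17 percentage points higher from compound 2 to compound 4 (beyond the scatter) and replacing chloro gave a number 14 percentage points higher from compound 1 to compound 4 (beyond the scatter) so all three steps point the same way, though each is modest. The position therefore does not leave the read-out flat whatever it carries, as the three earlier groups alone had suggested. Azido and dimethylamino have the same number of heavy atoms and the same hydrogen-bond counts, and they differ in azido's all-nitrogen makeup and its double bonds, but no measurement in hand ties the higher number to either feature or otherwise explains it.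

Going by these compounds, whether the rise is particular to azido or would also appear with other small groups at this carbon, such as a nitrile, an unsubstituted amine or a methoxy group, remains open. Also open, on these data alone, is how the azido compound would compare as a matter of potency, since the read-out comes from a single concentration and says nothing about the shape of a concentration response.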